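The compounds below may be only part of what the source reports. "The series", "measured", "known", "first", "only" and "open" are said of these compounds alone.

Compound 1, `CC(=O)N[C@@H]1CCCc2c1cncc2N1CCc2cc(Cl)ccc2C1=O`, is the starting point. In an ADME assay on cells for inhibition of cytochrome P450 11B1, mitochondrial (Homo sapiens), read by HTRF (a higher number here means a weaker inhibitor, a lower number a stronger inhibitor), compound 1 gives 3920 nM. Compound 2, `CCC(=O)N[C@@H]1CCCc2c1cncc2N1CCc2cc(Cl)ccc2C1=O`, carries one alteration relative to compound 1: methyl in place of hydrogen on a saturated chain carbon bound to a carbonyl carbon. In this assay compound 2 gives 3330 nM, and the change produced a 1.2-fold lower number from compound 1 to compound 2 (0.07 log units; within the scatter), so the two numbers cannot be told apart with confidence.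

Compound 3, `CC(=O)N[C@@H]1CCCc2c1cncc2N1Cc2cc(Cl)ccc2C1=O`, rests on a different core from compound 1; how the two cores differ is not broken down here. In this assay compound 3 gives 2330 nM. Its number sits within the scatter of both compound 1 and compound 2, so none of the three can be called the stronger or weaker inhibitor.

Compound 4, `CCC(=O)N[C@@H]1CCCc2c1cncc2N1Cc2cc(Cl)ccc2C1=O`, is not yet measured. It relates to compound 3 exactly as compound 2 relates to compound 1: methyl in place of hydrogen on a saturated chain carbon bound to a carbonyl carbon. The place of the change is worded the same in both pairs, so this is the same change carried onto the core of compound 3. Among the compounds with values here, the only guide to its effect is the earlier pair, where the step was a 1.2-fold lower number from compound 1 to compound 2 (0.07 log units; within the scatter), a size that amounts to no real movement. On that basis the step from compound 3 to compound 4 is expected to be about a 1.2-fold lower number from compound 3 to compound 4 (0.07 log units; within the scatter). Compound 4 is therefore estimated to give around 2000 nM in this assay, with a plausible range from 1000 nM to 4000 nM.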

Compound 4, half-maximal inhibitory concentration: 5210 nM
For compound 4 the middle estimate is 2.6-fold (0.42 log units) below the measured one; measured number above the stated range.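

Lengthening acetamido to propanoylamino on the core of compound 3 gives a 2.2-fold higher number from compound 3 to compound 4 (0.35 log units; beyond the scatter) in this assay, a modest step towards weaker inhibition, while the same change on the core of compound 1 gave a 1.2-fold lower number from compound 1 to compound 2 (0.07 log units; within the scatter). On paper the two steps point in opposite directions, but the gap between them is no larger than two such steps can show by chance: the same change on two cores in this assay, a 1.2-fold lower number (0.07 log units; within the scatter) from compound 1 to compound 2 and a 2.2-fold higher number (0.35 log units; beyond the scatter) from compound 3 to compound 4, 2.6-fold (0.42 log units) apart, within the scatter of two such steps So these two pairs do not show that the core alters what this methyl does, and they do not prove that its effect carries over unchanged either; with a single pair on each core, all that can be said is that compound 4 is a weaker inhibitor than compound 3, and that no difference between the cores can be claimed.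

The compounds shown leave open how a longer chain such as butanoyl, or a cyclopropyl group in place of the ethyl, would behave on either core in this assay. They also leave open whether the same change would give a clearer answer on a third core, or in a compound with a fluorine in place of the chlorine.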